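Swapping Cyano for Hydroxy: What Should Happen?

This account rests on a few compounds, and the source may have more. Where it says the series, first, only, none or still open, it means among the compounds named here.

Of the compounds shown here, three sharing one core have been tested in a functional assay on K562 cells (Homo sapiens) for antiproliferative activity, read by MTT assay, with a stated time of 48 h; a lower number here means a stronger inhibitor, a higher number a weaker inhibitor. Compound 1 `COc1ccc(CN2C(=O)C(=O)c3cc(-c4ccc(C(C)(C)C)cc4)ccc32)cc1`, carrying 4-(tert-butyl)phenyl, gives 2250 nM. Compound 2 `COc1ccc(CN2C(=O)C(=O)c3cc(-c4ccc(F)c(Cl)c4)ccc32)cc1`, carrying 3-chloro-4-fluorophenyl, gives 380 nM. Compound 3 `COc1ccc(CN2C(=O)C(=O)c3cc(-c4ccc(C#N)cc4)ccc32)cc1`, carrying 4-cyanophenyl, gives 260 nM, which is level with compound 2 within the scatter and clearly lower than compound 1.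

Compound 4 `COc1ccc(CN2C(=O)C(=O)c3cc(-c4ccc(O)cc4)ccc32)cc1` has hydroxy in place of cyano on an aromatic carbon, para to a large group: hydroxy in place of cyano on an aromatic carbon. Among the compounds with values here, no hydroxy compound has been measured, so any guidance is indirect. The closest change at that same carbon put cyano in place of tert-butyl and gave an 8.7-fold lower number from compound 1 to compound 3 (0.94 log units; beyond the scatter). Moving from 4-(tert-butyl)phenyl to 3-chloro-4-fluorophenyl gave a 5.9-fold lower number from compound 1 to compound 2 (0.77 log units; beyond the scatter). Both of these sizeable steps leave tert-butyl behind, which the new change does not do. Within the data shown here, the one step without tert-butyl gave only a 1.5-fold lower number from compound 2 to compound 3 (0.16 log units; within the scatter).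

In this assay, among the measured compounds shown here, then, no step clearly beyond the scatter is expected, with a slight lean towards a higher number. The estimated step is a 1.7-fold higher number from compound 3 to compound 4 (0.24 log units; within the scatter). Compound 4 is expected at 450 nM, with an estimated range from 130 nM to 1500 nM.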

Compound 4, half-maximal inhibitory concentration: 60 nM
Estimate against measurement, compound 4: 7.5-fold (0.88 log units) above; measured number below the stated range.
By their numbers in this assay, from the lowest: compound 4; then compounds 3 and 2 (each within the scatter of the next); then compound 1.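

In this assay, within the data shown here, the earlier compounds left it unclear whether this position could still move the number much once tert-butyl was gone, since the only step without it was a 1.5-fold lower number from compound 2 to compound 3 (0.16 log units; within the scatter). Hydroxy in place of cyano settles that with a 4.3-fold lower number from compound 3 to compound 4 (0.64 log units; beyond the scatter), showing that a small group at this carbon can shift the result beyond the scatter even when neither group is tert-butyl. The other two comparisons, a 6.3-fold lower number from compound 2 to compound 4 (0.80 log units; beyond the scatter) and a 38-fold lower number from compound 1 to compound 4 (1.57 log units; beyond the scatter), make compound 4 the strongest inhibitor of the four, but although hydroxy carries a hydrogen-bond donor that cyano lacks, nothing at hand explains the gain.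

The compounds shown leave open whether this gain is particular to hydroxy, or whether an amine, a carboxylic acid or a hydroxymethyl group at the same carbon would give a similar number. They also leave open whether the step from cyano to hydroxy would keep its size if another part of the shared core were changed.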